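One Added Methyl on a Weakly Active Ester

The source may report more compounds than this note shows. Statements on the series, on what has been measured and on what is new or still open speak of the compounds shown alone.

Measured in a functional assay on SW-620 cells (Homo sapiens) for antiproliferative activity, read by sulforhodamine B assay, with a stated time of 72 h; a higher number here means a weaker inhibitor, a lower number a stronger inhibitor:
- Compound 1 `COc1cc(/C=C/COC(C)=O)ccc1OC(C)=O`: 360 nM
- Compound 2 `CCCC(=O)OC/C=C/c1ccc(OC(C)=O)c(OC)c1`: 10200 nM

Compound 2 has the higher number of the pair, so it is the weaker inhibitor. Compound 3 `CC[C@H](C)C(=O)OC/C=C/c1ccc(OC(C)=O)c(OC)c1` alters it in one place: methyl in place of hydrogen on a saturated chain carbon bound to a carbonyl carbon and a saturated chain carbon. This turns propyl into sec-butyl. Going by the values given here, only one measured step bears on this change, and it was large: a 28-fold higher number from compound 1 to compound 2 (1.45 log units; beyond the scatter). That step added ethyl on a saturated chain carbon bound to a carbonyl carbon. The single methyl here is a smaller addition, so a smaller rise is expected in this assay, possibly none beyond the scatter. The expected change is a 1.5-fold higher number from compound 2 to compound 3 (0.17 log units; within the scatter). Compound 3 is estimated at 15000 nM, with an expected range of 5000 nM to 45000 nM.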

Compound 3, half-maximal inhibitory concentration: 21900 nM
The estimate for compound 3 lay 1.5-fold (0.16 log units) below the measured number, within the range that was stated.
By their numbers in this assay, from the lowest: compound 1; then compound 2; then compound 3.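

In this assay, even the single methyl that turns propyl into sec-butyl registers, with a 2.1-fold higher number from compound 2 to compound 3 (0.33 log units; beyond the scatter), so a modest rise continues beyond the large one seen earlier. Taken whole, sec-butyl in place of methyl on a carbonyl carbon gives a 61-fold higher number from compound 1 to compound 3 (1.78 log units; beyond the scatter), and across these three compounds each larger group carries a higher number. Nothing available explains this rise. From the compounds shown here alone, whether an unbranched pentyl chain would match sec-butyl remains open. So does whether an amine or a carboxylic acid on this chain would bring the number back down.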